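The compounds below may be only part of what the source reports. "The series", "measured", "known", "first", "only" and "open" are said of these compounds alone.

Of the compounds shown here, three have been measured in a functional assay on KB cells (Homo sapiens) for antiproliferative activity, read by sulforhodamine B assay, with a stated time of 72 h; on this read-out lower numbers stand for stronger inhibition of growth and higher numbers for weaker inhibition of growth. Compound 1, `CCc1cc(=O)c2ccc(Sc3cccc(Cl)[n+]3[O-])cc2o1`, reached only the limit of the assay, > 29900 nM. Compound 2, `CCc1cc(=O)c2ccc(Sc3cccc(Cl)[n+]3[O-])c(C)c2o1`, differs from compound 1 by methyl in place of hydrogen on an aromatic carbon. In this assay compound 2 also gave only a limit, > 28700 nM. Among the measured compounds shown here, with both results at limits, the step that the two limits leave unreadable from compound 1 to compound 2 cannot be read; the limits the limit of > 28700 nM in this assay, at which 1 of the 3 values shown sits, and the limit of > 29900 nM in this assay, at which 1 of the 3 values shown sits, show only that neither compound checked growth within the tested range. Compound 3, `CCc1cc(=O)c2ccc(OCc3ccccc3)c(C)c2o1`, has a different core; how its core differs from that of compound 1 is not broken down here. In this assay compound 3 likewise gave only a limit, > 33900 nM. Compound 4, `CCc1cc(=O)c2ccc(OCc3cccc(C)c3)c(C)c2o1`, is not yet measured; it differs from compound 3 by methyl in place of hydrogen on an aromatic carbon. This is the same kind of change as that from compound 1 to compound 2, but the place differs: in compound 2 the methyl sits on a ring that is part of a fused or bridged system of two rings, ortho to a fused ring and ortho to a group of 9 heavy atoms, whereas in compound 4 it sits meta to a large group. The step is expected to be about a step that the limit leaves unreadable from compound 3 to compound 4, because compound 3 itself gave only the limit > 33900 nM. Compound 4 is therefore expected to give roughly 40000 nM, with a likely span from 12000 nM to 150000 nM, and most probably only another limit.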

Compound 4, concentration for 50% growth inhibition: 28600 nM
Compound 4: middle estimate off by 1.4-fold (0.15 log units), on the high side; the measured number falls inside the stated range.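

In this assay, going from phenyl to 3-methylphenyl gives an at least 1.1-fold lower number from compound 3 to compound 4 (0.07 log units; that floor lies within the scatter), so this step shows no change in growth inhibition beyond the usual scatter, even though compound 4 alone of the four gives a number rather than a limit. The same kind of change, methyl in place of hydrogen on an aromatic carbon, cannot be read on the core of compound 1, because compound 1 and compound 2 both gave only limits: the limit of > 29900 nM in this assay, at which 1 of the 4 values shown sits. The series therefore does not show whether the effect of this change carries from one core to another, and the methyl also sits in a different place in compound 2 than in compound 4.

Going by these compounds, it remains open whether a different group on that phenyl ring, such as an amine, a carboxylic acid or a longer chain, would move the number beyond the scatter. On these data alone, it also remains open how a methyl would read where the starting compound gives a number rather than a limit.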